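The source may hold more compounds than are shown below. What is called first, only, known or untested is meant among the compounds shown, and "the series" means these compounds.

Three compounds sharing one core were read in a functional assay on T98G cells (Homo sapiens) for inhibition, read by MTT assay, with a stated time of 72 h; on this read-out lower numbers stand for stronger inhibition and higher numbers for weaker inhibition. Compound 1 `CC1(C)CC(NC(=O)Nc2ccccc2)c2cc(Cl)ccc2O1`, with phenyl on an amide-type nitrogen, gives 34000 nM. Compound 2 `CC1(C)CC(NC(=O)NCc2ccccc2)c2cc(Cl)ccc2O1`, with benzyl at that place, gives 15000 nM, and the change is a 2.3-fold lower number from compound 1 to compound 2 (0.36 log units; beyond the scatter). Compound 3 `CC(C)NC(=O)NC1CC(C)(C)Oc2ccc(Cl)cc21` carries isopropyl there. For compound 3 the assay reports only a limit, > 100000 nM.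

Compound 4 `CC1(C)CC(NC(=O)Nc2ccc(Cl)cc2)c2cc(Cl)ccc2O1` has 4-chlorophenyl in place of isopropyl on an amide-type nitrogen, (4-chlorophenyl in place of isopropyl on an amide-type nitrogen). The change brings back a six-membered aromatic ring of carbon only, as in the phenyl of compound 1. Going by the values given here, the steps that bear on it run the opposite way, since both put isopropyl in place of a group holding such a ring: an at least 2.9-fold higher number from compound 1 to compound 3 (0.46 log units; beyond the scatter) and an at least 6.6-fold higher number from compound 2 to compound 3 (0.82 log units; beyond the scatter). Reversing that change should therefore lower the number by at least a modest step. Among the compounds with values here, no measured step covers the added chlorine, so the expectation leans on compound 1 at 34000 nM and carries a wide range. The expected step is an at least 4.5-fold lower number from compound 3 to compound 4 (0.65 log units; beyond the scatter). Compound 4 is estimated at 22000 nM, with an expected range from 7000 nM to 70000 nM.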

Compound 4, half-maximal inhibitory concentration: 33000 nM
For compound 4 the middle estimate is 1.5-fold (0.18 log units) below the measured one; the measured number falls inside the stated range.
By their numbers in this assay, from the lowest: compound 2; then compounds 4 and 1 (each within the scatter of the next). At a limit, above all of these: compound 3.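

Going by these compounds alone, the chlorine is the part no earlier step covered, and in this assay chloro in place of hydrogen on an aromatic carbon gives a 1.0-fold lower number from compound 1 to compound 4 (0.01 log units; within the scatter), so this addition to the phenyl on the amide-type nitrogen produces no readable difference. A third group holding a six-membered aromatic ring of carbon only now goes with a lower number than isopropyl, with an at least 3.0-fold lower number from compound 3 to compound 4 (0.48 log units; beyond the scatter), although that step is only a bound, for compound 3 stands at a limit: the limit of > 100000 nM in this assay, at which 1 of the 4 values shown sits. Benzyl keeps the lowest number among the four compounds, and 4-chlorophenyl in its place gives a 2.2-fold higher number from compound 2 to compound 4 (0.34 log units; beyond the scatter).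

The compounds shown leave open whether a methoxy group or a carboxylic acid in place of the chloro would move the number, and whether a chloro on the benzyl of compound 2 would also leave it within the scatter. They also leave open whether a longer chain such as n-butyl, or a cyclohexyl group, on this nitrogen would read like isopropyl or like the groups holding an aromatic ring.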